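One Inverted Stereocentre, From Compound 3 to Compound 4

This account rests on a few compounds, and the source may have more. Where it says the series, first, only, none or still open, it means among the compounds named here.

Compound 1 `CC(=O)O[C@@H]1[C@@H](OC(C)=O)[C@H](O)[C@@H](CO)O[C@H]1NC(=S)NNC(=O)Cn1cnc2c(N)ncnc21`: >= 200000 nM in a functional assay on Bel-7402 cells (Homo sapiens) for cytotoxicity, read by MTT assay, with a stated time of 48 h; on this read-out lower numbers stand for an effect already at smaller amounts and higher numbers for an effect only at larger amounts of compound
Compound 2 `CC(=O)O[C@@H]1[C@@H](OC(C)=O)[C@@H](O)[C@@H](CO)O[C@H]1NC(=S)NNC(=O)Cn1cnc2c(N)ncnc21`: 86200 nM
Compound 3 `CC(=O)O[C@@H]1[C@@H](OC(C)=O)[C@H](O)[C@@H](CO)O[C@H]1NC(=S)NNC(=O)Cn1cnc2ccccc21`: > 100000 nM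

Compound 3 reaches only a limit of this assay, and its value is therefore not a number. Compound 1 likewise sits at a limit of this assay. Because of the limit of >= 200000 nM in this assay, at which 1 of the 3 values shown sits, and (the limit of > 100000 nM in this assay, at which 1 of the 3 values shown sits), the step that the two limits leave unreadable from compound 1 to compound 3 cannot be read.

Compound 4 `CC(=O)O[C@@H]1[C@@H](OC(C)=O)[C@@H](O)[C@@H](CO)O[C@H]1NC(=S)NNC(=O)Cn1cnc2ccccc21` is not yet measured. It differs from compound 3 thus: the two compounds have the same atoms and bonds and differ only in configuration as drawn: 1 of 5 stereo elements differ; a stereocentre at a saturated ring carbon is drawn R in compound 3 and S in compound 4

The same inversion has been seen once before, in the pair built on the other aromatic group: the step of an at least 2.3-fold lower number from compound 1 to compound 2 (0.36 log units; beyond the scatter) can be traced to configuration alone because of the fact that compounds 1 and 2 differ only in the configuration as drawn. That step is the only one bearing on the present change, and it points towards a lower number for compound 4 in this assay.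

Since compound 3 offers only a limit, the starting point of the step is uncertain, and the outcome may again be a limit. Compound 4 is nevertheless expected to give 60000 nM in this assay, within 25000 nM to 200000 nM. The expected step is an at least 1.6-fold lower number from compound 3 to compound 4 (0.22 log units; that floor lies within the scatter), in the direction seen from compound 1 to compound 2.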

Compound 4, half-maximal effective concentration: > 200000 nM
Compound 4: only a limit was reported; the forecaster's own chance of this, stated with the estimate: 40%; at least 3.3-fold (0.52 log units) between middle value and limit.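

With the group of 9 heavy atoms in place, inverting the stereocentre at the saturated ring carbon yields no value that can be read as a number: compound 3 and compound 4 both stand at a limit of this assay, and the steps that join two limits cannot be read. With that ring carbon drawn S, however, exchanging the group of 10 heavy atoms for the group of 9 heavy atoms has a readable size, an at least 2.3-fold higher number from compound 2 to compound 4 (0.36 log units; beyond the scatter). The lower number that went with the inversion, an at least 2.3-fold lower number from compound 1 to compound 2 (0.36 log units; beyond the scatter), thus has no readable counterpart in the second pair, which is separated by nothing but configuration: the fact that compounds 3 and 4 differ only in the configuration as drawn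

From the compounds shown here alone, how far apart compound 3 and compound 4 actually lie remains unknown, as does whether the S configuration goes with a lower number only when the group of 10 heavy atoms is present. Also open, going by these compounds, is how an amine or a carboxylic acid, in place of these aromatic groups on the saturated chain carbon bound to the carbonyl carbon, would read in this assay.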